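Removing the methyl from the aryl of compound 1

This account rests on a few compounds, and the source may have more. Where it says the series, first, only, none or still open, it means among the compounds named here.

Measured so far:
- compound 1, `Cc1cccc([C@@H](O)C(=O)N2N=CC[C@H]2C(=O)NCc2cc(Cl)ccc2-n2cnnn2)c1`: 830 nM
- compound 2, `CC(C)(C)C[C@@H](O)C(=O)N1CC[C@@H]2C[C@@]21C(=O)NCc1cc(Cl)ccc1-n1cnnn1`: 620 nM

In a functional assay on a cell-free system (plasma, Homo sapiens), with a stated time of 3 min (on this read-out lower numbers stand for stronger inhibition and higher numbers for weaker inhibition), compound 1 gives 830 nM and compound 2 gives 620 nM; compound 1 holds the higher of the two numbers, yet the gap to compound 2 lies within the scatter, so the pair shows no difference worth reading. Compound 3, `O=C(NCc1cc(Cl)ccc1-n1cnnn1)[C@@H]1CC=NN1C(=O)[C@H](O)c1ccccc1`, is not yet measured. It differs from compound 1 by hydrogen in place of methyl on an aromatic carbon. Nothing measured here speaks to that change. The step from compound 1 to compound 3 is expected to stay within the scatter, a 1.2-fold higher number from compound 1 to compound 3 (0.08 log units; within the scatter), if anything leaning toward a slightly higher number. Compound 3 is estimated at 1000 nM, in the range 400 nM to 2500 nM.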

Compound 3, half-maximal inhibitory concentration: 840 nM
Compound 3: the middle estimate sits 1.2-fold (0.08 log units) above what was measured, within the range that was stated.
By their numbers in this assay, from the lowest: compounds 2, 1 and 3 (each within the scatter of the next).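

Among these compounds, this is the first one-place comparison: in this assay, the change from 3-methylphenyl to phenyl gives a 1.0-fold higher number from compound 1 to compound 3 (0.01 log units; within the scatter) and so shows no readable change. On this aromatic carbon, meta to a large group, the methyl is therefore not needed to hold the number on the core of compound 1. No accompanying measurement bears on this result.

Open, as far as these compounds go, is whether a methoxy, an amine or a carboxylic acid at this position would also leave the number unchanged. Also open, from the compounds shown here alone, is whether hydrogen in place of methyl reads the same at other carbons of this aromatic ring.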